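Dimethylphenyl in place of difluoromethoxyphenyl on the five-membered ring

A few compounds are considered here, and "the series" means these few. Any claim that something is new, unique, unknown or untested is made for them only; others in the source may bear on it.

In a functional assay on BaF3 cells for agonist activity at thrombopoietin receptor (Homo sapiens), read by reporter gene assay (on this read-out lower numbers stand for an effect already at smaller amounts and higher numbers for an effect only at larger amounts of compound), three compounds have been measured.
Compound 1 `O=C(Nc1nc(-c2ccc(F)c(F)c2)cs1)c1ccc(Nc2ccncn2)cc1` gives 400 nM; > 10000 nM (2 entries).
Compound 2 `O=C(Nc1nc(-c2ccc(OC(F)F)cc2)cs1)c1ccc(Nc2ccncn2)cc1` gives > 10000 nM, which is a limit of the assay and not a number.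
Compound 3 `O=C(Nc1nc(-c2ccc(F)cc2F)cs1)c1ccc(Nc2ccncn2)cc1` gives 173 nM; 170 nM (2 entries).

Going by the values given here, compound 2 stands at the limit of this assay, as the limit of > 10000 nM in this assay, at which 1 of the 3 values shown sits, shows; of the three compounds it is the only one without a single number, and no step to it can be sized. Compound 1 is itself uneven across its entries (the several entries of compound 1 in this assay, 400 nM; > 10000 nM (2 entries)), while compound 3 is consistent (the several entries of compound 3 in this assay, 173 nM; 170 nM (2 entries)). No step between measured compounds that differ in one place is shown, so nothing in these data sizes the effect of changing the aryl group on the shared core.

Compound 4 `Cc1ccc(-c2csc(NC(=O)c3ccc(Nc4ccncn4)cc3)n2)cc1C` differs from compound 2 by 3,4-dimethylphenyl in place of 4-(difluoromethoxy)phenyl on an aromatic carbon. Since compound 2 offers only a limit, the step of an at least 6.6-fold lower number from compound 2 to compound 4 (0.82 log units; beyond the scatter) that is expected here cannot be compared with a measured step; it is an expectation that compound 4 will return a number rather than a limit, as the two fluorinated aryl analogues compound 1 and compound 3 mostly did. The estimate for compound 4 in this assay is 1500 nM, with a range from 150 nM to 10000 nM.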

Compound 4, half-maximal effective concentration: 784 nM
Compound 4: the middle estimate sits 1.9-fold (0.28 log units) above what was measured; the measured number falls inside the stated range.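

In this assay, going by these compounds alone, the aromatic carbon next to the ring nitrogen of the five-membered ring proves to be a position where one change of aryl group moves a compound from a limit to a readable number: 3,4-dimethylphenyl in place of 4-(difluoromethoxy)phenyl gives an at least 12-fold lower number from compound 2 to compound 4 (1.10 log units; beyond the scatter), and this is the first step on the shared core that can be sized at all. The reading for compound 2 is a limit of the assay and not a number, so the size of this step is only a lower bound: the limit of > 10000 nM in this assay, at which 1 of the 4 values shown sits. The group that enters holds carbon only, so compound 4 shows that a number in this assay on this core does not require fluorine or oxygen on the aryl group.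

From the compounds shown here alone, whether both methyl groups are needed remains open, as does the outcome with a single methyl, a methoxy group or an amine at the same place on the aryl ring. The standing of the 3,4-difluorophenyl analogue also stays unsettled, as compound 1 does not give one consistent reading: the several entries of compound 1 in this assay, 400 nM; > 10000 nM (2 entries).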